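The source may hold more compounds than are shown below. What is called first, only, known or untested is meant among the compounds shown, and "the series" means these compounds.

Of the compounds shown here, three that share one core have been tested in a functional assay for antagonist activity at Vanilloid receptor (Rattus norvegicus); on this read-out lower numbers stand for stronger inhibition and higher numbers for weaker inhibition. Compound 1 `CC(C)(C)c1ccc(C/N=C(\S)NCc2ccc(C(F)(F)F)cc2)cc1` gives 12400 nM. Compound 2 `CCS(=O)(=O)Nc1ccc(C/N=C(\S)NCc2ccc(C(C)(C)C)cc2)cc1`, which carries an ethyl chain on the sulfonyl sulfur, gives 1300 nM. Compound 3 `CCCS(=O)(=O)Nc1ccc(C/N=C(\S)NCc2ccc(C(C)(C)C)cc2)cc1`, with a propyl chain in that place, gives 4500 nM. Among these three numbers compound 3 stands second highest: the single change from compound 2 to compound 3 is a 3.5-fold higher number from compound 2 to compound 3 (0.54 log units; beyond the scatter), a clear weakening, while compound 1 sits somewhat higher still.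

Compound 4 `CCCCS(=O)(=O)Nc1ccc(C/N=C(\S)NCc2ccc(C(C)(C)C)cc2)cc1` differs from compound 3 only by methyl in place of hydrogen on a saturated chain carbon, three bonds along the chain from a sulfonyl sulfur. Just one measured step bears on this change: lengthening the same chain from ethyl to propyl, a 3.5-fold higher number from compound 2 to compound 3 (0.54 log units; beyond the scatter), pushed the number up beyond the scatter. Among the measured compounds shown here, whether a further lengthening carries on in the same direction is not known from these data, yet the one step available points upward. The step from compound 3 to compound 4 is therefore expected to be a 1.8-fold higher number from compound 3 to compound 4 (0.25 log units; within the scatter), a milder weakening than before. Compound 4 is estimated at 8000 nM, within a range from 3000 nM to 22000 nM.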

Compound 4, half-maximal inhibitory concentration: 4100 nM
Compound 4: the middle estimate sits 2.0-fold (0.29 log units) above what was measured; low and high end bracket the measured number.
By their numbers in this assay, from the lowest: compound 2; then compounds 4 and 3 (each within the scatter of the next); then compound 1.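

Going from propyl to butyl gives a 1.1-fold lower number from compound 3 to compound 4 (0.04 log units; within the scatter) in this assay, so the methyl added three bonds along the chain from the sulfonyl sulfur leaves no readable difference, unlike the methyl added two bonds along, which gave a 3.5-fold higher number from compound 2 to compound 3 (0.54 log units; beyond the scatter). Set against the ethyl chain, the butyl chain gives a 3.2-fold higher number from compound 2 to compound 4 (0.50 log units; beyond the scatter), so among these three chains the higher number appears with propyl and stays at butyl instead of climbing with each added carbon. Nothing available explains why the change at this place reads so differently from the one before it.

As far as these compounds go, whether a longer chain such as pentyl or hexyl would keep the number level remains open. So does whether a methyl group on the sulfonyl sulfur, in place of the ethyl chain, would give a lower number than compound 2.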